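A few compounds are considered here, and "the series" means these few. Any claim that something is new, unique, unknown or untested is made for them only; others in the source may bear on it.

Working notes on the series

Compound 1 `COc1ncnc2c1c(-c1cccs1)cn2[C@@H]1O[C@H](CO)[C@@H](O)[C@H]1O` is the reference point: in a functional assay on HL-60 cells (Homo sapiens) for antiproliferative activity, read by XTT assay, with a stated time of 72 h (on this read-out higher numbers stand for weaker inhibition and lower numbers for stronger inhibition), compound 1 gives 80 nM. Compound 2 `COc1nc(N)nc2c1c(-c1cccs1)cn2[C@@H]1O[C@H](CO)[C@@H](O)[C@H]1O` carries an amino in place of hydrogen on an aromatic carbon. For compound 2 the read-out is a limit of the assay, > 20000 nM, not a number; the same limit appears as the limit of > 20000 nM in this assay, at which 1 of the 3 values shown sits. The step is an at least 250-fold higher number from compound 1 to compound 2 (2.39 log units; beyond the scatter), and its true size may be larger than the limit shows.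

Compound 3 `O=c1[nH]cnc2c1c(-c1ccco1)cn2[C@@H]1O[C@H](CO)[C@@H](O)[C@H]1O` gives 2200 nM in this assay; the difference between its core and that of compound 1 is not broken down here. Compound 4 `Nc1nc2c(c(-c3ccco3)cn2[C@@H]2O[C@H](CO)[C@@H](O)[C@H]2O)c(=O)[nH]1` has not yet been measured. It relates to compound 3 by the same kind of change, amino in place of hydrogen on an aromatic carbon, although the surroundings differ: in compound 1 the entering group sits meta to a methoxy group (2 heavy atoms), in compound 3 meta to a group of 1 heavy atom.

Given the size of an at least 250-fold higher number from compound 1 to compound 2 (2.39 log units; beyond the scatter), compound 4 is expected to lose strongly, with an estimated step of an 18-fold higher number from compound 3 to compound 4 (1.26 log units; beyond the scatter). Compound 4 is thus estimated at 40000 nM, within 8000 nM to 200000 nM, and a limit is the likeliest outcome.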

Compound 4, half-maximal inhibitory concentration: > 20000 nM
Compound 4: no number, only a limit; the forecaster's own chance of this, stated with the estimate: 70%; the middle value does not contradict the limit.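

In this assay compound 4 gives > 20000 nM, which is a limit of the assay and not a number. Amino in place of hydrogen on an aromatic carbon again weakens inhibition, with an at least 9.0-fold higher number from compound 3 to compound 4 (0.95 log units; beyond the scatter), so the change goes the same way on the core of compound 1 and on the core of compound 3. This does not show how large the change is on either core, or whether it is larger on one of them: the same change on two cores in this assay, an at least 250-fold higher number (2.39 log units; beyond the scatter) from compound 1 to compound 2 and an at least 9.0-fold higher number (0.95 log units; beyond the scatter) from compound 3 to compound 4; the limit leaves it open whether they differ

The compounds shown leave open whether a group other than amino at this place, such as methyl, chlorine or dimethylamino, would keep the inhibition seen without it. On these data alone, compound 1 and compound 3 also differ in more than one place, so it remains open which part of the core, if any, would alter the size of this change.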